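Trading the benzamide aryl group for a small methoxy

The compounds below may be only part of what the source reports. "The series", "measured", "known", "first", "only" and "open" are said of these compounds alone.

Three triazenes built on one shared core differ only in the group attached to the carbonyl carbon. In a functional assay on HeLa cells (Homo sapiens) for cytotoxicity, read by MTT assay, with a stated time of 72 h (on this read-out higher numbers stand for weaker inhibition and lower numbers for stronger inhibition), compound 1 `O=C(c1ccccc1C(F)(F)F)N(/N=N/c1ccc([N+](=O)[O-])cc1Cl)c1ccc([N+](=O)[O-])cc1Cl` gives 10600 nM, compound 2 `O=C(c1cccc(C(F)(F)F)c1)N(/N=N/c1ccc([N+](=O)[O-])cc1Cl)c1ccc([N+](=O)[O-])cc1Cl` gives 1180 nM, and compound 3 `O=C(c1ccc(C(F)(F)F)cc1)N(/N=N/c1ccc([N+](=O)[O-])cc1Cl)c1ccc([N+](=O)[O-])cc1Cl` gives 1060 nM, the lowest of the three numbers, although the step of a 1.1-fold lower number from compound 2 to compound 3 (0.05 log units; within the scatter) lies within the scatter. Shifting the trifluoromethyl group around the ring gave a 9.0-fold lower number from compound 1 to compound 2 (0.95 log units; beyond the scatter) and a 10-fold lower number from compound 1 to compound 3 (1.00 log units; beyond the scatter). Compound 4 `COC(=O)N(/N=N/c1ccc([N+](=O)[O-])cc1Cl)c1ccc([N+](=O)[O-])cc1Cl` carries methoxy in place of 4-(trifluoromethyl)phenyl on a carbonyl carbon. Within the data shown here, no measured step swaps the whole aromatic group for something this small, so the measured steps bear only loosely on the change, and the expectation is a modest rise in the number with wide uncertainty. Compound 4 is expected to give 5000 nM, within 1000 nM to 25000 nM, an estimated step of a 4.7-fold higher number from compound 3 to compound 4 (0.67 log units; beyond the scatter).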

Compound 4, half-maximal inhibitory concentration: 980 nM
Compound 4: the middle estimate sits 5.1-fold (0.71 log units) above what was measured; measured number below the stated range.
By their numbers in this assay, from the lowest: compounds 4, 3 and 2 (each within the scatter of the next); then compound 1.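

In this assay, the aromatic ring on the carbonyl carbon proves dispensable: methoxy in place of 4-(trifluoromethyl)phenyl gives no real change (a 1.1-fold lower number from compound 3 to compound 4 (0.03 log units; within the scatter)), and neither does methoxy in place of 3-(trifluoromethyl)phenyl (a 1.2-fold lower number from compound 2 to compound 4 (0.08 log units; within the scatter)). Methoxy in place of 2-(trifluoromethyl)phenyl gives a clear step (an 11-fold lower number from compound 1 to compound 4 (1.03 log units; beyond the scatter)), so among these four compounds only compound 1 stands apart. Nothing at hand explains why so small a group matches the larger ones. From the compounds shown here alone, whether an amine or a longer chain such as butoxy on the carbonyl carbon would also leave the number unchanged remains open.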